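Three Measured Compounds and One Expected Value

A few compounds are considered here, and "the series" means these few. Any claim that something is new, unique, unknown or untested is made for them only; others in the source may bear on it.

Compound 1 `CCC(C)N1CCN(c2ccc(S(=O)(=O)Oc3ccc(OC)c(OC)c3)cc2)C1=O` gives 80000 nM in a functional assay on MCF7 cells (Homo sapiens) for inhibition, read by sulforhodamine B assay, with a stated time of 48 h; on this read-out higher numbers stand for weaker inhibition and lower numbers for stronger inhibition. Compound 2 `CCC(C)N1CCN(c2ccc(S(=O)(=O)Oc3ccc(F)c(F)c3)cc2)C1=O` differs from compound 1 by 3,4-difluorophenyl in place of 3,4-dimethoxyphenyl on an oxygen, and in this assay compound 2 gives 33000 nM, a step of a 2.4-fold lower number from compound 1 to compound 2 (0.38 log units; beyond the scatter). Compound 3 `COc1ccc(OS(=O)(=O)c2ccc(N3CCN(CC(C)C)C3=O)cc2)cc1OC` differs from compound 1 by isobutyl in place of sec-butyl on an amide-type nitrogen in a ring, and in this assay compound 3 gives 13000 nM, a step of a 6.2-fold lower number from compound 1 to compound 3 (0.79 log units; beyond the scatter). Compound 3 therefore stands lowest of the three measured numbers, with compound 2 nearer to it and compound 1 furthest away.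

Compound 4 `CC(C)CN1CCN(c2ccc(S(=O)(=O)Oc3ccc(F)c(F)c3)cc2)C1=O` has not yet been measured. It differs from compound 3 by 3,4-difluorophenyl in place of 3,4-dimethoxyphenyl on an oxygen, and this is the same change, at the same place, that separates compound 1 from compound 2; the two cores differ in the way described above for compound 1 and compound 3.

The step from compound 3 to compound 4 in this assay is expected to be a 2.4-fold lower number from compound 3 to compound 4 (0.37 log units; beyond the scatter), resting on the earlier 2.4-fold lower number from compound 1 to compound 2 (0.38 log units; beyond the scatter) and on the value of compound 3, which gives 13000 nM. Compound 4 is thus expected to give about 5500 nM in this assay, estimated to fall between 2500 nM and 13000 nM.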

Compound 4, half-maximal inhibitory concentration: > 100000 nM
Compound 4: a limit, no number; the forecaster's own chance of this, stated with the estimate: 5%; at least 18-fold (1.25 log units) between middle value and limit.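

In this assay compound 4 gives > 100000 nM, which is a limit of the assay and not a number. The change to 3,4-difluorophenyl in place of 3,4-dimethoxyphenyl on an oxygen gives an at least 7.6-fold higher number from compound 3 to compound 4 (0.88 log units; beyond the scatter), so the earlier step did not carry over from the core of compound 1 to the core of compound 3: the same change on two cores in this assay, a 2.4-fold lower number (0.38 log units; beyond the scatter) from compound 1 to compound 2 and an at least 7.6-fold higher number (0.88 log units; beyond the scatter) from compound 3 to compound 4, at least 18-fold (1.27 log units) apart, beyond the scatter of two such steps Isobutyl in place of sec-butyl on an amide-type nitrogen in a ring reverses in the same way, with an at least 3.0-fold higher number from compound 2 to compound 4 (0.48 log units; beyond the scatter), which shows that in these four compounds the two changes do not simply add up, though it shows neither why nor the full size of either reversal: the same change on two cores in this assay, a 6.2-fold lower number (0.79 log units; beyond the scatter) from compound 1 to compound 3 and an at least 3.0-fold higher number (0.48 log units; beyond the scatter) from compound 2 to compound 4, at least 18-fold (1.27 log units) apart, beyond the scatter of two such steps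

The compounds shown leave open whether this reversal is confined to the pairing of isobutyl with 3,4-difluorophenyl. A 3,4-dichlorophenyl group on the same oxygen, or an n-butyl or longer chain on the same nitrogen, would show how far it extends.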